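Chloromethylbenzyl series: amino for chloro on the shared core

The source may hold more compounds than are shown below. What is called first, only, known or untested is meant among the compounds shown, and "the series" means these compounds.

Measured in a functional assay on SF-295 cells (Homo sapiens) for cytotoxicity, read by sulforhodamine B assay, with a stated time of 48 h; on this read-out lower numbers stand for stronger inhibition of growth and higher numbers for weaker inhibition of growth:
- compound 1 `ClCc1ccc(Cn2cnc3c(Cl)ncnc32)cc1` gives 3460 nM
- compound 2 `ClCc1ccccc1Cn1cnc2c(Cl)nc(Cl)nc21` gives 3380 nM
- compound 3 `ClCc1cccc(Cn2cnc3nc(Cl)nc(Cl)c32)c1` gives 3380 nM

The three numbers sit on top of one another: compound 2 and compound 3 agree at the digits read, and compound 1 is no further from compound 2 than the scatter of repeated runs allows. The values of compound 2 and compound 1 therefore show no difference that can be read as a change; the same holds for compound 2 against compound 3. Among the compounds with values here, nothing so far separates one compound from another.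

Compound 4 `Nc1nc(Cl)c2ncn(Cc3ccccc3CCl)c2n1` has not been measured. It differs from compound 2 by amino in place of chloro on an aromatic carbon. Within the data shown here, no pair of measured compounds tracks this exchange, so the expectation rests on the flat picture of the three measured values alone. The expected step from compound 2 to compound 4 in this assay is a 1.0-fold higher number from compound 2 to compound 4 (0.02 log units; within the scatter), in either direction no more than the scatter. For compound 4 the estimated value is 3500 nM, with a range from 1200 nM to 10000 nM.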

Compound 4, concentration for total growth inhibition: 23400 nM
The estimate for compound 4 lay 6.7-fold (0.83 log units) below the measured number, outside the stated range (above it).
By their numbers in this assay, from the lowest: compounds 2, 3 and 1 (each within the scatter of the next); then compound 4.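

In this assay, within the data shown here, amino in place of chloro on the aromatic carbon between two ring nitrogen atoms gives a 6.9-fold higher number from compound 2 to compound 4 (0.84 log units; beyond the scatter) and is the first step in these notes beyond the scatter. The three flat earlier values gave no sign that this position mattered, yet here a single exchange on the shared core, with the chloromethylbenzyl part unchanged, separates compound 4 from compound 2.

On these data alone, this rests on one pair, so it remains open whether other groups at this carbon, such as methoxy or methylamino, would give a step of similar size, or whether the same exchange would carry over to the other chloromethylbenzyl compounds. Nothing among the data shown explains the step.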